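Replacing Fluoro with Cyano in Compound 1

The source may report more compounds than this note shows. Statements on the series, on what has been measured and on what is new or still open speak of the compounds shown alone.

In a functional assay on HepG2 cells (Homo sapiens) for inhibition, read by MTT assay, with a stated time of 24 h (on this read-out higher numbers stand for weaker inhibition and lower numbers for stronger inhibition), compound 1 (`COc1ccc(/C=N/NC(=O)CNC(=O)c2ccc(F)cc2)c(OCc2ccccc2Cl)c1`) gives 15700 nM. Among the measured compounds shown here, the only other measured compound, compound 2 (`O=C(CNC(=O)c1ccc(F)cc1)N/N=C/c1ccccc1OCc1ccccc1Cl`), gives 24900 nM, so the two lie within the usual scatter of each other and neither can be ranked ahead. Compound 3 (`COc1ccc(/C=N/NC(=O)CNC(=O)c2ccc(C#N)cc2)c(OCc2ccccc2Cl)c1`) has not been measured yet. It keeps the core of compound 1 and puts cyano in place of fluoro on an aromatic carbon, para to a large group: cyano in place of fluoro on an aromatic carbon. For the measured compounds named here, the single measured step, a 1.6-fold higher number from compound 1 to compound 2 (0.20 log units; within the scatter), is a different edit, hydrogen in place of methoxy on an aromatic carbon. It bears only indirectly, showing one small edit of compound 1 that stayed within the scatter. Going by the values given here, no measured compound carries the cyano group, so the data point in neither direction, and no step beyond the scatter is expected. The expected step is a 1.0-fold lower number from compound 1 to compound 3 (0.02 log units; within the scatter). In this assay, the estimate for compound 3 is 15000 nM, with an expected range from 6000 nM to 40000 nM.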

Compound 3, half-maximal inhibitory concentration: > 50000 nM
Compound 3 ended at the assay's limit (the forecaster's own chance of this, stated with the estimate: 8%); at least 3.3-fold (0.52 log units) between middle value and limit.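

Among the compounds shown here, the position para to a large group is not a silent one in this assay: cyano in place of fluoro gives an at least 3.1-fold higher number from compound 1 to compound 3 (0.50 log units; beyond the scatter), which means clearly weaker inhibition and is the first step to pass beyond the scatter. Compound 3 reads > 50000 nM, which is a limit of the assay and not a number, so the step has a floor but no known upper end: the limit of > 50000 nM in this assay, at which 1 of the 3 values shown sits. For the compounds shown here, the only earlier step, a 1.6-fold higher number from compound 1 to compound 2 (0.20 log units; within the scatter), concerned methoxy at a different place and could not be told apart from the scatter, so the fluoro position is the one place so far where a single edit has moved the read-out measurably.

This single swap does not separate what cyano adds from what the loss of fluoro removes, and it gives no reason for the drop in inhibition. As far as these compounds go, how an amine, a carboxylic acid or plain hydrogen at this position would read remains open, as does whether cyano would have the same effect on compound 2, which has no methoxy.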